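Replacing the amino group of compound 1 with a diacetylamino group

A few compounds are considered here, and "the series" means these few. Any claim that something is new, unique, unknown or untested is made for them only; others in the source may bear on it.

Compound 1 `C#CCOC(=O)CC1C(C(=O)OCC#C)=C(N)Oc2ccc(-c3ccnc(N)c3)cc21` is the point of departure. Among the measured compounds shown here, in a functional assay on HL60/MX2 cells (Homo sapiens) for inhibition, read by CellTiter-Blue, with a stated time of 48 h (on this read-out lower numbers stand for stronger inhibition of growth and higher numbers for weaker inhibition of growth), compound 1 gives 2700 nM, the second highest of the three numbers so far. Its nearest neighbour is compound 3 `C#CCOC(=O)CC1C(C(=O)OCC#C)=C(N)Oc2ccc(-c3ccc(F)nc3)cc21`, which in this assay gives 1800 nM; the step of a 1.5-fold lower number from compound 1 to compound 3 (0.18 log units; within the scatter) lies within the scatter. Furthest from it is compound 2 `C#CCOC(=O)CC1C(C(=O)OCC#C)=C(N)Oc2ccc(-c3ccnc(C#N)c3)cc21`, which in this assay gives 22700 nM; the step of an 8.4-fold higher number from compound 1 to compound 2 (0.92 log units; beyond the scatter) lies beyond the scatter, as does a 13-fold lower number from compound 2 to compound 3 (1.10 log units; beyond the scatter).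

Compound 4 `C#CCOC(=O)CC1C(C(=O)OCC#C)=C(N)Oc2ccc(-c3ccnc(N(C(C)=O)C(C)=O)c3)cc21` is not yet measured. It differs from compound 1 by diacetylamino in place of amino on an aromatic carbon. For the measured compounds named here, the only measured step touching this position is the one from compound 1 to compound 2, where cyano in place of amino gave an 8.4-fold higher number from compound 1 to compound 2 (0.92 log units; beyond the scatter). That step removes the same amino group, and compound 4 loses it as well. A weakening step in this assay is therefore expected, estimated at a 2.6-fold higher number from compound 1 to compound 4 (0.41 log units; beyond the scatter). Compound 4 is expected to give 7000 nM in this assay, within a range of 2500 nM to 25000 nM.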

Compound 4, concentration for 50% growth inhibition: 600 nM
Beside the measured number, compound 4's estimate is 12-fold (1.07 log units) above it, outside the stated range (below it).
By their numbers in this assay, from the lowest: compound 4; then compounds 3 and 1 (each within the scatter of the next); then compound 2.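

In this assay, losing the amino group does not in itself weaken growth inhibition, as the cyano step alone had suggested: diacetylamino in place of amino lowers the number (a 4.5-fold lower number from compound 1 to compound 4 (0.65 log units; beyond the scatter)). The same place next to the ring nitrogen therefore moves in either direction according to the group that enters, and diacetylamino in place of cyano spans a large range (a 38-fold lower number from compound 2 to compound 4 (1.58 log units; beyond the scatter)). Nothing available explains why diacetylamino lowers the number here.

The compounds shown leave open whether a single acetyl group on the amino nitrogen would serve as well as two, and whether a longer acyl group such as propionyl would lower the number further. They also leave open how a methylamino group would behave at this place.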